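2-Methyl-1,3-oxazol-5-yl in Place of 4-Methyl-1H-imidazol-1-yl

The source may hold more compounds than are shown below. What is called first, only, known or untested is meant among the compounds shown, and "the series" means these compounds.

Compound 1 `COc1cc(N2CCN(C(=O)NCc3cccc4ccccc34)CC2)ccc1-c1cnc(C)o1` and compound 2 `COc1cc(N2CCN(C(=O)N[C@@H](C)c3cccc4ccccc34)CC2)ccc1-n1cnc(C)c1` have both been run in an ADME assay on microsomes from liver (Rattus norvegicus) for metabolic stability, read by LC-MS; on this read-out lower numbers stand for slow clearance and higher numbers for fast clearance. There compound 1 gives 160 mL.min-1.g-1, and compound 2 gives 150 mL.min-1.g-1; the two numbers lie within the usual scatter of each other, so neither can be set above the other. Compound 3 `COc1cc(N2CCN(C(=O)N[C@@H](C)c3cccc4ccccc34)CC2)ccc1-c1cnc(C)o1` arises from compound 2 by a single change: 2-methyl-1,3-oxazol-5-yl in place of 4-methyl-1H-imidazol-1-yl on an aromatic carbon. Among the compounds with values here, no measured pair isolates this change, so nothing points to a step beyond the scatter in either direction. In this assay the expected step is no change at the digits printed from compound 2 to compound 3 (within the scatter). Compound 3 is accordingly estimated at 150 mL.min-1.g-1, within a range from 75 mL.min-1.g-1 to 300 mL.min-1.g-1.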

Compound 3, intrinsic clearance in microsomes: 130 mL.min-1.g-1
Compound 3: middle estimate off by 1.2-fold (0.06 log units), on the high side, and the stated range covers the measured number.
By their numbers in this assay, from the lowest: compounds 3, 2 and 1 (each within the scatter of the next).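

In this assay, within the data shown here, 2-methyl-1,3-oxazol-5-yl in place of 4-methyl-1H-imidazol-1-yl on the aromatic carbon ortho to a methoxy group gives a 1.2-fold lower number from compound 2 to compound 3 (0.06 log units; within the scatter) and so leaves the read-out within the scatter, a first measured pair for this position. Methyl in place of hydrogen on the saturated chain carbon likewise gives a 1.2-fold lower number from compound 1 to compound 3 (0.09 log units; within the scatter) and stays within the scatter. Nothing available explains either step. Both exchanges therefore leave clearance fast, and the compounds shown leave open whether a group of another kind at this position, such as an amine or a carboxylic acid, would give a step beyond the scatter.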